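This account rests on a few compounds, and the source may have more. Where it says the series, first, only, none or still open, it means among the compounds named here.

Compound 1 `CN(c1ccccc1Cl)S(=O)(=O)C1CC2OC1C(c1ccc(NC(=O)CCCCCCC(=O)O)cc1)=C2c1ccc(O)cc1` sits at the lowest number among three measured compounds in a functional assay on MCF7 cells (Homo sapiens) for antiproliferative activity, read by MTT assay, with a stated time of 72 h (on this read-out higher numbers stand for weaker inhibition and lower numbers for stronger inhibition), where compound 1 gives 12800 nM. Compound 2 `CN(c1cccc2ccccc12)S(=O)(=O)C1CC2OC1C(c1ccc(NC(=O)CCCCCCC(=O)O)cc1)=C2c1ccc(O)cc1` gives 14000 nM, and the step of a 1.1-fold higher number from compound 1 to compound 2 (0.04 log units; within the scatter) lies within the scatter. Compound 3 `CCN(c1cccc(OC)c1)S(=O)(=O)C1CC2OC1C(c1ccc(NC(=O)CCCCCCC(=O)O)cc1)=C2c1ccc(O)cc1` gives 37400 nM, and the steps of a 2.9-fold higher number from compound 1 to compound 3 (0.47 log units; beyond the scatter) and a 2.7-fold higher number from compound 2 to compound 3 (0.43 log units; beyond the scatter) go beyond the scatter, though each of these steps alters both the aryl group and the small alkyl group on the sulfonamide nitrogen at once.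

Compound 4 `CCN(c1ccccc1Cl)S(=O)(=O)C1CC2OC1C(c1ccc(NC(=O)CCCCCCC(=O)O)cc1)=C2c1ccc(O)cc1` differs from compound 1 by a single change: methyl in place of hydrogen on a saturated chain carbon bound to a sulfonamide nitrogen. Among the compounds with values here, no measured step isolates this change; the only two steps that include the methyl-to-ethyl exchange also exchange the aryl group, so they bear on it only loosely, and they point to a modest weakening at most. A small step toward a higher number is therefore expected, but one that may well remain within the scatter.

For compound 4 the expected value in this assay is 16000 nM, with a range from 8000 nM to 32000 nM. The expected step is a 1.3-fold higher number from compound 1 to compound 4 (0.10 log units; within the scatter).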

Compound 4, half-maximal inhibitory concentration: 33300 nM
Compound 4: the middle estimate sits 2.1-fold (0.32 log units) below what was measured; measured number outside the range, above it.
By their numbers in this assay, from the lowest: compounds 1 and 2 (each within the scatter of the next); then compounds 4 and 3 (each within the scatter of the next).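

In this assay, methyl in place of hydrogen on a saturated chain carbon bound to a sulfonamide nitrogen gives a 2.6-fold higher number from compound 1 to compound 4 (0.42 log units; beyond the scatter) and so shows that the methyl-to-ethyl exchange with the 2-chlorophenyl group held fixed is enough for a step beyond the scatter. With ethyl held on the nitrogen, 2-chlorophenyl in place of 3-methoxyphenyl gives a 1.1-fold lower number from compound 3 to compound 4 (0.05 log units; within the scatter) and so separates the two aryl groups by no more than the scatter. The remaining step of a 2.4-fold higher number from compound 2 to compound 4 (0.38 log units; beyond the scatter) changes the aryl group and the alkyl group together and cannot be read for this position alone.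

Going by these compounds, whether a propyl or cyclopropylmethyl group on the sulfonamide nitrogen would continue this step remains open. No evidence at hand accounts for the step.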